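The source may report more compounds than this note shows. Statements on the series, on what has been measured and on what is new or still open speak of the compounds shown alone.

Going by the values given here, in a functional assay on HT-29 cells (Homo sapiens) for inhibition, with a stated time of 72 h (a lower number here means a stronger inhibitor, a higher number a weaker inhibitor), compound 1 `COc1ccc(S(=O)(=O)N2CCc3cccc(-c4ccc(F)c(F)c4)c32)cc1` gives 57 nM, the lower of the two numbers so far. Compound 2 `COc1ccc(S(=O)(=O)N2CCc3cccc(-c4cc(OC)c(OC)c(OC)c4)c32)cc1` gives 5100 nM, a gap beyond the scatter. Compound 3 `COc1ccc(S(=O)(=O)N2CCc3cccc(-c4ccccc4)c32)cc1` is still unmeasured and has phenyl in place of 3,4-difluorophenyl on an aromatic carbon. Among the compounds with values here, no measured pair isolates this change, so the expectation rests on the structural change alone. The estimated step is a 1.8-fold higher number from compound 1 to compound 3 (0.24 log units; within the scatter), a small move toward weaker inhibition that is not expected to clear the scatter. For compound 3 the expected value is 100 nM, with an estimated range of 30 nM to 350 nM.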

Compound 3, half-maximal inhibitory concentration: 96.5 nM
Compound 3: middle estimate off by 1.0-fold (0.02 log units), on the high side; the range from low to high includes it.
By their numbers in this assay, from the lowest: compounds 1 and 3 (each within the scatter of the next); then compound 2.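

Phenyl in place of 3,4-difluorophenyl gives a 1.7-fold higher number from compound 1 to compound 3 (0.23 log units; within the scatter) in this assay, so at this aromatic carbon the two fluorines are not needed to keep a number in the range of compound 1. Compound 2 also lacks fluorine and has the much higher number 5100 nM. Lacking fluorine is not all that separates it from compound 1. Nothing available explains why phenyl and 3,4-difluorophenyl read alike here.

Still open, from the compounds shown here alone, is whether one methoxy group on the phenyl already raises the number, or whether several are needed. Going by these compounds, how an amine or a carboxylic acid on that phenyl would read is also open.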